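The source may hold more compounds than are shown below. What is called first, only, known or untested is meant among the compounds shown, and "the series" means these compounds.

Compound 1 `O=C(/C=C/c1ccc(O)cc1)c1c(O)cccc1OCC1CCCCC1`, compound 2 `CC(C)=CCOc1cccc(O)c1C(=O)/C=C/c1ccc(O)cc1` and compound 3 `O=C(/C=C/c1ccc(O)cc1)c1c(O)cccc1OCc1ccccc1` share one core and differ only in the group on a saturated chain carbon bound to an oxygen on an aromatic ring. In a functional assay on NCI-H23 cells (Homo sapiens) for antiproliferative activity, read by sulforhodamine B assay (a higher number here means a weaker inhibitor of growth, a lower number a stronger inhibitor of growth), compound 1 gives > 30000 nM, a limit of the assay and not a number. In this assay compound 2 gives > 30000 nM, again a limit. In this assay compound 3 gives > 30000 nM, also a limit. Compound 3 thus stands at the same limit as the other two, as summarised by the limit of > 30000 nM in this assay, at which 3 of the 3 values shown sit. The steps a step that the two limits leave unreadable from compound 1 to compound 2, a step that the two limits leave unreadable from compound 1 to compound 3 and a step that the two limits leave unreadable from compound 2 to compound 3 are all left unreadable by limits on both sides. Compound 4 `CC(C)CCCOc1cccc(O)c1C(=O)/C=C/c1ccc(O)cc1` differs from compound 3 by isopentyl in place of phenyl on a saturated chain carbon bound to an oxygen on an aromatic ring. Only these three unreadable steps bear on the change, so no size can be drawn from them; cyclohexyl, 2-methylprop-1-en-1-yl and phenyl in this place all left growth inhibition at the limit. Compound 4 is therefore expected to stay at the limit in this assay as well, a step that the limit leaves unreadable from compound 3 to compound 4. Compound 4 is estimated at 45000 nM, range 15000 nM to 150000 nM.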

Compound 4, concentration for 50% growth inhibition: 11400 nM
Estimate against measurement, compound 4: 3.9-fold (0.60 log units) above, outside the stated range (below it).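

In this assay this position can move growth inhibition: with isopentyl on the saturated chain carbon bound to an oxygen on an aromatic ring, compound 4 gives 11400 nM as a measured number and not a limit. The change reads as an at least 2.6-fold lower number from compound 3 to compound 4 (0.42 log units; beyond the scatter) and an at least 2.6-fold lower number from compound 2 to compound 4 (0.42 log units; beyond the scatter) and an at least 2.6-fold lower number from compound 1 to compound 4 (0.42 log units; beyond the scatter) with each step beyond the scatter and its full size hidden. Lack of a ring in the group is not enough, as compound 2 with 2-methylprop-1-en-1-yl also has none and stays at a limit, and compound 4 remains the lone readable value: the limit of > 30000 nM in this assay, at which 3 of the 4 values shown sit.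

From the compounds shown here alone, whether a longer chain such as octyl, or a chain ending in an amine or a carboxylic acid, would take growth inhibition further stays open. Also open, going by these compounds, is the true size of these steps, each of which rests on a limit.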